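Notes on a phenyl replacement at a carbonyl carbon

The source may hold more compounds than are shown below. What is called first, only, known or untested is meant among the compounds shown, and "the series" means these compounds.

In a functional assay on RAW264.7 cells (Mus musculus) for inhibition, read by Griess assay, with stated times of 3 h and 24 h (a higher number here means a weaker inhibitor, a lower number a stronger inhibitor), compound 1 (`C=C1CC[C@H]2[C@@](C)(CCC(=O)N[C@@]2(C)CO)[C@@H]1/C=C/C1=CCOC1=O`) gives > 50000 nM, which is a limit of the assay and not a number. Compound 2 (`C=C1CC[C@H]2[C@@](C)(CCC(=O)N[C@@]2(C)COC(=O)CCCC[C@@H]2CCSS2)[C@@H]1/C=C/C1=CCOC1=O`) gives 22400 nM. Compound 3 (`C=C1CC[C@H]2[C@@](C)(CC[C@@H](OC(=O)c3ccccc3)[C@@]2(C)NC=O)[C@@H]1/C=C/C1=CCOC1=O`) gives 50000 nM, and this is the higher of the two actual numbers. The gap to compound 2 is beyond the scatter.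

Compound 4 (`C=C1CC[C@H]2[C@@](C)(CC[C@@H](OC(=O)CCCC[C@@H]3CCSS3)[C@@]2(C)NC=O)[C@@H]1/C=C/C1=CCOC1=O`) differs from compound 3 on a carbonyl carbon: a group of 9 heavy atoms (7 carbon, 2 sulfur; one five-membered non-aromatic ring with 2 hetero atoms) in place of a group of 6 heavy atoms (6 carbon; one six-membered aromatic ring of carbon only), on a carbonyl carbon.

For the measured compounds named here, one measured step bears on this change: an at least 2.2-fold lower number from compound 1 to compound 2 (0.34 log units; beyond the scatter). It brings in the same kind of five-membered non-aromatic ring with 2 hetero atoms, but there the group replaces a hydrogen atom on an oxygen, not a phenyl. Going by these compounds, its starting point is also the limit, (the limit of > 50000 nM in this assay, at which 1 of the 3 values shown sits), so its full size is unknown. The transfer to compound 4 is therefore uncertain, although the direction from compound 2 at 22400 nM favours a lower number in this assay.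

The expected change is a modest one, a 2.5-fold lower number from compound 3 to compound 4 (0.40 log units; beyond the scatter). For compound 4 the estimated value is 20000 nM, with an expected range of 7000 nM to 50000 nM.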

Compound 4, half-maximal inhibitory concentration: > 50000 nM
Compound 4: only a limit was reported (the forecaster's own chance of this, stated with the estimate: 15%); at least 2.5-fold (0.39 log units) between middle value and limit.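

Compound 4 gives > 50000 nM in this assay, which is a limit of the assay and not a number. Replacing phenyl on this carbonyl carbon with the group carrying the five-membered non-aromatic ring with 2 hetero atoms gives a number no lower from compound 3 to compound 4 (the limit leaves the size open), so the earlier lower number, an at least 2.2-fold lower number from compound 1 to compound 2 (0.34 log units; beyond the scatter), does not carry over to this position. With compound 4, the readable range of the series narrows further, and comparisons at this position are now restricted by the assay ceiling: the limit of > 50000 nM in this assay, at which 2 of the 4 values shown sit.

Going by these compounds, how far compound 4 lies past its limit remains open, so the size of the step cannot be read. Also open, on these data alone, is whether an amine or a carboxylic acid on this carbonyl carbon, in place of phenyl, would give a number clearly below the limit in this assay.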